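A Halogen and Acid Swap on the Phenyl Ether

A few compounds are considered here, and "the series" means these few. Any claim that something is new, unique, unknown or untested is made for them only; others in the source may bear on it.

Of the compounds shown here, two have been measured so far. Compound 1 `Cc1ccc(C(=O)O)cc1OCCCCOc1ccc(C(=O)CC(C)C)c(O)c1C` gives 76.9% in an assay on HEK293 cells for positive allosteric modulation of metabotropic glutamate receptor 2 (Rattus norvegicus), read by thallium flux, with a stated time of 2.5 min; a higher number here means a larger maximal response, a lower number a smaller maximal response. Compound 2 `Cc1c(OCCCCOc2ccc(C(=O)O)c(Cl)c2)ccc(C(=O)CC(C)C)c1O` gives 80.5% in this assay. Within the data shown here, the only step between them, a number 3.6 percentage points higher from compound 1 to compound 2 (within the scatter), lies within the scatter, so compound 2 is not set apart from compound 1 by these numbers; they simply sit close together.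

Compound 3 `Cc1c(OCCCCOc2ccc(F)c(C(=O)O)c2)ccc(C(=O)CC(C)C)c1O` changes the same phenyl ether end of the molecule once more: 3-carboxy-4-fluorophenyl in place of 4-carboxy-3-chlorophenyl on an oxygen on a saturated carbon. Among the measured compounds shown here, the one measured step that bears on this place, a number 3.6 percentage points higher from compound 1 to compound 2 (within the scatter), swapped the whole aryl group on that oxygen and produced no change beyond the scatter. On that basis the expected step from compound 2 to compound 3 in this assay is small, a number 0.5 percentage points lower from compound 2 to compound 3 (within the scatter), with no clear direction. The estimate for compound 3 in this assay is therefore 80%, with a range from 66% to 92%.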

Compound 3, largest response reached (reported as percent of maximum), in percent of the reference or control that the assay uses: 84.5%
Beside the measured number, compound 3's estimate is 4.5 percentage points below it; the range from low to high includes it.
By their numbers in this assay, from the lowest: compounds 1, 2 and 3 (each within the scatter of the next).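

Putting 3-carboxy-4-fluorophenyl in place of 4-carboxy-3-chlorophenyl in this assay gives a number 4 percentage points higher from compound 2 to compound 3 (within the scatter), and putting it in place of 5-carboxy-2-methylphenyl gives a number 7.6 percentage points higher from compound 1 to compound 3 (within the scatter). With a third aryl group on this oxygen, the scatter still separates none of the three compounds, even though the carboxy group sits at a different ring position in compound 3 than in compound 2 and fluorine replaces chlorine. Nothing available explains why these swaps leave the maximal response so close.

From the compounds shown here alone, all three compounds carry a carboxylic acid on this ring, so how a primary amide or a tetrazole there would read remains open. Only the aryl end varies here, which also leaves open what a shorter or longer chain would do.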